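Removing a Trifluoromethyl Group: What to Expect

This account rests on a few compounds, and the source may have more. Where it says the series, first, only, none or still open, it means among the compounds named here.

Of the compounds shown here, two have so far been tested in a functional assay on Bel-7402 cells (Homo sapiens) for antiproliferative activity, read by sulforhodamine B assay, tested at 100 ug/mL; on this read-out lower numbers stand for less inhibition and higher numbers for more inhibition at the one concentration tested (going by the name of the read-out). Compound 1 `Cc1ccc(NS(=O)(=O)C2CCCCC2=O)cc1` gives 27.5% in this assay. Compound 2 `O=C1CCCCC1S(=O)(=O)Nc1ccc(Cl)cc1C(F)(F)F` gives 21% in this assay, the lowest of the two numbers, although its nearest neighbour, compound 1, stands within the scatter of that number, so the two cannot be told apart. Both show only modest inhibition at the single concentration tested.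

Compound 3 `O=C1CCCCC1S(=O)(=O)Nc1ccc(Cl)cc1` has not yet been measured. It differs from compound 2 in one place: hydrogen in place of trifluoromethyl on an aromatic carbon. Among the compounds with values here, no pair of measured compounds differing in just one place exists here, so there is no measured step to lean on, and nothing is known about what removing this group does on its own. Within the data shown here, with only two numbers available, both low and indistinguishable from each other, the most reasonable expectation is that compound 3 stays in the same low region, and the expected change is a number 3 percentage points higher from compound 2 to compound 3 (within the scatter), that is, none beyond the scatter in either direction. Compound 3 is accordingly estimated to give 24% in this assay, with a range from 10% to 40%.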

Compound 3, a percentage reported as inhibition, at one concentration (the size of the read-out at that concentration, not a potency): 4.47%
Compound 3: middle estimate off by 19.5 percentage points, on the high side; the whole stated range lies above it.
By their numbers in this assay, from the lowest: compound 3; then compounds 2 and 1 (each within the scatter of the next).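

In this assay, the trifluoromethyl group on this aromatic carbon, ortho to a large group, proves to matter: putting hydrogen in its place gives a number 16.5 percentage points lower from compound 2 to compound 3 (beyond the scatter). The other single change, chloro in place of methyl on an aromatic carbon, gives a number 23 percentage points lower from compound 1 to compound 3 (beyond the scatter), so compound 3, which carries chloro but neither methyl nor trifluoromethyl, is the lowest of the three and shows very little inhibition at the one concentration tested. Nothing available here explains why either change lowers the number.

As far as these compounds go, it remains open whether trifluoromethyl is special at this position or whether another group on the same aromatic carbon, such as an amine or a methoxy group, would also bring the number back up to the level of compound 2. These readings also give only the size of inhibition at a single concentration, so they leave open how the compounds would compare across a range of concentrations.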